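This account rests on a few compounds, and the source may have more. Where it says the series, first, only, none or still open, it means among the compounds named here.

Compound 1, `CCCCCc1ccc(-c2cn(C/C=C3\OC(=O)C(OCc4ccccc4)=C3OCc3ccccc3)nn2)cc1`: in a functional assay on CFPAC-1 cells (Homo sapiens) for antiproliferative activity, read by MTT assay, with a stated time of 72 h (a lower number here means a stronger inhibitor, a higher number a weaker inhibitor), compound 1 gives > 100000 nM, which is a limit of the assay rather than a number.
Compound 2, `COc1ccccc1-c1cn(C[C@H](O)[C@H]2OC(=O)C(OCc3ccccc3)=C2OCc2ccccc2)nn1`: in this assay compound 2 gives > 100000 nM, again a limit.
Compound 3, `COc1ccc(-c2cn(C/C=C3\OC(=O)C(OCc4ccccc4)=C3OCc3ccccc3)nn2)cc1`: in this assay compound 3 gives > 100000 nM, also a limit.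

The three measured compounds share a core and differ only in the aromatic group attached to the five-membered aromatic ring with three nitrogens. None of them reached a measurable value: all three sit at the same limit, (the limit of > 100000 nM in this assay, at which 3 of the 3 values shown sit). Compound 2 therefore stands nowhere in particular on the numbers shown; it is simply one of three compounds whose activity was too weak to be read. Within the data shown here, the single step between measured compounds, a step that the two limits leave unreadable from compound 1 to compound 3, is unreadable for the same reason, since both of its ends are limits.

Compound 4, `O=C1O[C@H]([C@@H](O)Cn2cc(-c3cc(F)cc(F)c3)nn2)C(OCc2ccccc2)=C1OCc1ccccc1`, differs from compound 2 by 3,5-difluorophenyl in place of 2-methoxyphenyl on an aromatic carbon. Among the measured compounds shown here, no measured step bears readably on this change, so there is no basis for expecting a shift in this assay in either direction beyond the scatter. The step of a number no higher from compound 2 to compound 4 (the limit leaves the size open) is expected to be none that can be seen. Compound 4 is accordingly estimated at 100000 nM, within a range from 30000 nM to 300000 nM, most likely reported again as a limit.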

Compound 4, half-maximal inhibitory concentration: 62400 nM
The estimate for compound 4 lay 1.6-fold (0.20 log units) above the measured number; the measured number falls inside the stated range.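

Compound 4 is the only one of the four shown that gives a true number in this assay, 62400 nM, so a compound with a group on this aromatic carbon of the five-membered ring can reach the readable range. Putting 3,5-difluorophenyl in place of 2-methoxyphenyl gives an at least 1.6-fold lower number from compound 2 to compound 4 (0.20 log units; that floor lies within the scatter); one end of this step is a limit, so only a floor can be stated, and that floor alone does not establish a real change. The value of compound 4 is therefore a first fixed point for the series, whose other readings remain limits: the limit of > 100000 nM in this assay, at which 3 of the 4 values shown sit.

Since the swap removes the methoxy group and brings in two fluorines at once, the compounds shown cannot tell which part of the change matters, or whether the placement of these groups on the phenyl ring plays any role. A 4-fluorophenyl, a 3-aminophenyl or a phenyl carrying a carboxylic acid at this place would show whether the value can move clearly beyond the scatter, and in which direction.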